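The source may hold more compounds than are shown below. What is called first, only, known or untested is meant among the compounds shown, and "the series" means these compounds.

Compound 1, `COc1ccc(-c2nc3cccc(-c4cc(OC)c(OC)c(OC)c4)c3o2)cc1`, in a functional assay on U-251 cells (Homo sapiens) for antiproliferative activity, read by MTT assay, with a stated time of 48 h (on this read-out lower numbers stand for stronger inhibition and higher numbers for weaker inhibition), gives > 25000 nM, which is a limit of the assay rather than a number.
Compound 2, `COc1cccc(-c2nc3cccc(-c4cc(OC)c(OC)c(OC)c4)c3o2)c1`, in this assay gives > 25000 nM, again only a limit.
Compound 3, `COc1cc(-c2cccc3nc(-c4ccc(F)cc4)oc23)cc(OC)c1OC`, in this assay gives > 25000 nM, again only a limit.

In this assay compound 2 therefore stands only at a limit, and the other two values shown do the same: all three sit at the limit of > 25000 nM in this assay, at which 3 of the 3 values shown sit. The change to the unmeasured compound 4, `COc1cc(-c2cccc3nc(-c4cccs4)oc23)cc(OC)c1OC`, is thiophen-2-yl in place of 3-methoxyphenyl on an aromatic carbon. The measured steps that bear on it are swaps of the same group on the same carbon: a step that the two limits leave unreadable from compound 1 to compound 2, a step that the two limits leave unreadable from compound 1 to compound 3 and a step that the two limits leave unreadable from compound 2 to compound 3, none of which can be read in size, as both of their ends are limits. No measured step thus supplies a size or a direction, and nothing shown separates any of the three compounds from another beyond the scatter. Compound 4 is expected to remain at or near the same limit, with an estimated 30000 nM (range 8000 nM to 120000 nM). The step from compound 2 to compound 4 is accordingly expected to be a step that the limit leaves unreadable from compound 2 to compound 4, with a strong chance that only a limit is reported again.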

Compound 4, half-maximal inhibitory concentration: 3000 nM
Compound 4: middle estimate off by 10-fold (1.00 log units), on the high side, outside the stated range (below it).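

In this assay, the aromatic carbon of the five-membered ring with nitrogen and oxygen proves able to change the result: placing thiophen-2-yl there gives an at least 8.3-fold lower number from compound 2 to compound 4 (0.92 log units; beyond the scatter), along with an at least 8.3-fold lower number from compound 3 to compound 4 (0.92 log units; beyond the scatter) and an at least 8.3-fold lower number from compound 1 to compound 4 (0.92 log units; beyond the scatter). One end of each of these steps is a limit, so they give only a minimum size, and the true difference could be larger. The steps among compound 1, compound 2 and compound 3 cannot be read, and all three share one limit: the limit of > 25000 nM in this assay, at which 3 of the 4 values shown sit.

Going by these compounds, it remains open whether the change depends on the sulfur atom or on the smaller five-membered ring, a question that furan-2-yl, thiophen-3-yl or an unsubstituted phenyl at the same place could help to separate. On these data alone, it is also open whether compound 4 would behave the same way on cells other than U-251.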